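This account rests on a few compounds, and the source may have more. Where it says the series, first, only, none or still open, it means among the compounds named here.

Of the compounds shown here, three of one family have been tested so far, and all carry the same chain: a nitrile and a carbonyl on a double-bonded chain carbon, with an aromatic ring on the neighbouring carbon. Compound 1 `N#C/C(=C\c1c[nH]c2ccccc12)C(=O)c1c[nH]c2ccccc12` bears two indole rings, compound 2 `N#C/C(=C\c1ccco1)C(=O)NCc1ccc(Cl)c(Cl)c1` a furan on the chain and a dichlorobenzyl amide, and compound 3 `COc1ccc(CNC(=O)/C(C#N)=C/c2ccc(Br)o2)cc1` a bromofuran on the chain and a methoxybenzyl amide.

In a functional assay on MIA cells (Homo sapiens) for inhibition, read by MTT assay, with a stated time of 72 h (on this read-out lower numbers stand for stronger inhibition of growth and higher numbers for weaker inhibition of growth), compound 1 gives 14000 nM. In this assay compound 3 gives 16000 nM. For compound 2 this assay reports only a limit, > 50000 nM, so compound 2 is the one that sits at the limit of > 50000 nM in this assay, at which 1 of the 3 values shown sits, and stands at the weak end of everything shown.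

Compound 4 `COc1ccc(/C=C(\C#N)C(=O)NCc2ccc(Cl)c(Cl)c2)cc1` has not yet been tested. It differs from compound 2 in one place: 4-methoxyphenyl in place of furan-2-yl on a double-bonded chain carbon bound to a double-bonded chain carbon. Within the data shown here, no measured pair of compounds isolates this exchange, so the size of its effect has to be guessed from the whole set.

Since the two compounds with numbers, compound 1 and compound 3, both sit well inside the measurable range, compound 4 is expected to move from the limit of compound 2 toward stronger inhibition, a step of roughly an at least 2.5-fold lower number from compound 2 to compound 4 (0.39 log units; beyond the scatter). In this assay compound 4 is estimated at 20000 nM, most likely between 5000 nM and 60000 nM.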

Compound 4, concentration for 50% growth inhibition: 79000 nM
The estimate for compound 4 lay 4.0-fold (0.60 log units) below the measured number, outside the stated range (above it).
By their numbers in this assay, from the lowest: compounds 1 and 3 (each within the scatter of the next); then compound 4.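

The step from compound 2 to compound 4 cannot be read, since compound 2 carries a limit and not a number: the limit of > 50000 nM in this assay, at which 1 of the 4 values shown sits. The compounds shown leave open how much 4-methoxyphenyl in place of furan-2-yl changes inhibition of growth in this assay when both partners of such a pair have readable numbers.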